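A Methyl for Two Chlorines on the Aniline Ring

This account rests on a few compounds, and the source may have more. Where it says the series, first, only, none or still open, it means among the compounds named here.

Among the compounds with values here, compound 3 `COc1cc(/C=C/C(=O)c2sc(Nc3ccc(Cl)c(Cl)c3)nc2C)cc(OC)c1OC` is one of three compounds measured in a functional assay on BGC-823 cells (Homo sapiens) for cytotoxicity, read by MTT assay; a lower number here means a stronger inhibitor, a higher number a weaker inhibitor. In this assay, as far as these compounds go, compound 3 reaches only > 25000 nM, which is a limit of the assay and not a number, so where it truly stands is unknown. Compound 1 `Cc1nc(Nc2cccc(Cl)c2)sc1C(=O)/C=C/c1ccccc1` likewise stops at the limit, giving > 25000 nM in this assay. Compound 2 `Cc1nc(Nc2ccccc2)sc1C(=O)/C=C/c1ccccc1` is the only one of the three with a number, giving 19500 nM in this assay. Compound 3 therefore sits at the limit of > 25000 nM in this assay, at which 2 of the 3 values shown sit.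

Compound 4 `COc1cc(/C=C/C(=O)c2sc(Nc3ccccc3C)nc2C)cc(OC)c1OC` differs from compound 3 by 2-methylphenyl in place of 3,4-dichlorophenyl on a nitrogen on an aromatic ring. Within the data shown here, the only measured step that resembles this change is an at least 1.2-fold lower number from compound 1 to compound 2 (0.10 log units; that floor lies within the scatter), in which a chlorine leaves an aromatic carbon; that step stays within the scatter. The change to compound 4 is larger, trading a 3,4-dichlorophenyl for a 2-methylphenyl, yet nothing measured shows such a trade moving the number beyond the scatter. Compound 4 is therefore expected to remain near the limit, at an estimated 22000 nM (range 8000 nM to 60000 nM) in this assay. That amounts to an estimated at least 1.1-fold lower number from compound 3 to compound 4 (0.05 log units; that floor lies within the scatter) in this assay.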

Compound 4, half-maximal inhibitory concentration: 5400 nM
The estimate for compound 4 lay 4.1-fold (0.61 log units) above the measured number; measured number below the stated range.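

In this assay, 2-methylphenyl in place of 3,4-dichlorophenyl on this nitrogen gives an at least 4.6-fold lower number from compound 3 to compound 4 (0.66 log units; beyond the scatter), so the group at this position can change the result by more than the scatter. The earlier step at this nitrogen, an at least 1.2-fold lower number from compound 1 to compound 2 (0.10 log units; that floor lies within the scatter), did not show this, since its floor stayed within the scatter. Compound 3 stands at a limit of the assay, so the size of the new step is only a floor, and the true gap may be larger because the assay gives no number for compound 3: the limit of > 25000 nM in this assay, at which 2 of the 4 values shown sit.

The change removes two chlorines and adds a methyl in one move, so the compounds shown cannot tell which part of it matters. As far as these compounds go, how a methoxy group or an amine on this ring would read on the core of compound 3 also stays open.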